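The source may report more compounds than this note shows. Statements on the series, on what has been measured and on what is new or still open speak of the compounds shown alone.

Of the compounds shown here, three built on one shared core have been tested in an ADME assay on L929 cells (Mus musculus, culture collection number NCTC 929) for cytotoxicity, read by MTT assay, with a stated time of 72 h; on this read-out higher numbers stand for weaker inhibition and lower numbers for stronger inhibition. Within the data shown here, compound 1 `CCCCCCCCc1c(O)cc(C)oc1=O` gives 145000 nM, and this is the only plain number among the three. Compound 2 `Cc1cc(O)c(C(=S)Nc2ccccc2)c(=O)o1` returns only a limit of the assay, > 200000 nM. Compound 3 `Cc1cc(O)c(CC2CCCCC2)c(=O)o1` likewise returns only a limit, > 200000 nM. Among the measured compounds shown here, compound 1 therefore stands alone as the one compound with a measured number; the other two sit at the limit of > 200000 nM in this assay, at which 2 of the 3 values shown sit.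

Compound 4 `CCCCCCCCCCc1c(O)cc(C)oc1=O` has not yet been measured. It differs from compound 1 by ethyl in place of hydrogen on a saturated chain carbon, eight bonds along the chain from an aromatic carbon. For the measured compounds named here, no pair of measured compounds here differs in a single place, so the data give no direct guide to how adding carbons to the chain changes the read-out. The change from compound 1 to compound 4 in this assay is expected to be modest, leaning toward stronger inhibition, a 1.8-fold lower number from compound 1 to compound 4 (0.26 log units; within the scatter), though it may well stay within the scatter. Compound 4 is estimated to give about 80000 nM, with a likely range from 30000 nM to 200000 nM.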

Compound 4, half-maximal inhibitory concentration: 56000 nM
Beside the measured number, compound 4's estimate is 1.4-fold (0.15 log units) above it, and the stated range covers the measured number.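

Among these compounds, the change gives the first step in this assay that can be read: ethyl in place of hydrogen on a saturated chain carbon, eight bonds along the chain from an aromatic carbon, gives a 2.6-fold lower number from compound 1 to compound 4 (0.41 log units; beyond the scatter). The read-out therefore responds to a change at this place on the chain, and it moves toward stronger inhibition, although this single modest step shows a direction for one pair and not a trend. Compound 2 and compound 3 each return only a limit of the assay, so no step to either of them can be read: the limit of > 200000 nM in this assay, at which 2 of the 4 values shown sit.

From the compounds shown here alone, whether a longer chain would carry the shift further remains open. Also open, going by these compounds, is what a chain bearing an amine or a carboxylic acid would give in this assay.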